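The compounds below may be only part of what the source reports. "The series", "measured", "known", "first", "only" and "open" are said of these compounds alone.

Compound 1, `COc1ccc(-c2c(Cl)c(=O)c3c(OC)cc(OC)cc3n2S(=O)(=O)c2ccc(OC)cc2)cc1`: 90000 nM
Compound 2, `COc1ccc(-c2c(Br)c(=O)c3c(OC)cc(OC)cc3n2S(=O)(=O)c2ccc(OC)cc2)cc1`: 49700 nM
Compound 3, `COc1ccc(-c2cc(=O)c3c(OC)cc(OC)cc3n2S(=O)(=O)c2cccc([N+](=O)[O-])c2)cc1`: > 39600 nM

All three were measured in an ADME assay on BJ cells (Homo sapiens) for antiproliferative activity, with a stated time of 72 h; a lower number here means that less compound is needed, a higher number that more compound is needed for the effect. Compound 1 gives 90000 nM and compound 2 gives 49700 nM, with a 1.8-fold lower number from compound 1 to compound 2 (0.26 log units; within the scatter). Among the compounds with values here, for compound 3 the result is only a limit of the assay, > 39600 nM, so no number is known for it; it is the one value sitting at the limit of > 39600 nM in this assay, at which 1 of the 3 values shown sits.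

Compound 4, `COc1ccc(-c2cc(=O)c3c(OC)cc(OC)cc3n2S(=O)(=O)c2ccc(Br)s2)cc1`, has not yet been measured in this assay. It differs from compound 3 in one place: 5-bromothiophen-2-yl in place of 3-nitrophenyl on a sulfonyl sulfur. Within the data shown here, the only measured step, a 1.8-fold lower number from compound 1 to compound 2 (0.26 log units; within the scatter), concerns a halogen on the shared core and not the group on the sulfonyl sulfur, so no measured step bears directly on this change; what the data show is that the one single-point change measured stayed within the scatter.

The step that the limit leaves unreadable from compound 3 to compound 4 is therefore expected to be small, and compound 4 is estimated at 60000 nM, within 25000 nM to 150000 nM, with a fair chance that this assay again reports only a limit.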

Compound 4, half-maximal effective concentration: > 48200 nM
Compound 4 was reported as a limit; the forecaster's own chance of this, stated with the estimate: 45%; the middle value does not contradict the limit.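

In this assay compound 3 gives > 39600 nM as a limit of the assay. Compound 4 gives > 48200 nM as a limit too. Within the data shown here, with only limits, no step from compound 3 to compound 4 can be read. On these data alone, whether 5-bromothiophen-2-yl and 3-nitrophenyl on the sulfonyl sulfur differ at all remains open.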